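Hydroxy in Place of Methoxy: An Expected Limit

The source may report more compounds than this note shows. Statements on the series, on what has been measured and on what is new or still open speak of the compounds shown alone.

Measured compounds:
compound 1, `O=C(Nc1cccc(-n2cc(-c3ccncc3)c(-c3ccc(Cl)c(O)c3)n2)c1)Nc1cccc(C(F)(F)F)c1`: > 32500 nM
compound 2, `COc1cc(-c2nn(-c3cccc(NC(=O)Nc4ccc(Cl)c(C(F)(F)F)c4)c3)cc2-c2ccncc2)ccc1Cl`: > 32500 nM

Both measured compounds were tested in a functional assay on SR cells (Homo sapiens) for inhibition, read by sulforhodamine B assay, with a stated time of 48 h; a higher number here means that more compound is tolerated, a lower number that less compound is tolerated. For compound 2 the result is a limit of the assay rather than a number, at > 32500 nM. For compound 1 the result is likewise a limit, at > 32500 nM. Within the data shown here, compound 2 therefore stands where the only other value stands: both results sit at the limit of > 32500 nM in this assay, at which 2 of the 2 values shown sit, and no step between measured compounds can be drawn from them.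

The next compound, compound 3, has the structure `O=C(Nc1cccc(-n2cc(-c3ccncc3)c(-c3ccc(Cl)c(O)c3)n2)c1)Nc1ccc(Cl)c(C(F)(F)F)c1`. It differs from compound 2 in one place: hydrogen in place of methyl on an oxygen on an aromatic ring.

Among the measured compounds shown here, since no measured step is available, the expectation for compound 3 in this assay rests on the two limits alone. Because both measured compounds sit at the limit of > 32500 nM in this assay, at which 2 of the 2 values shown sit, compound 3 is expected to remain at the limit as well, so that the step from compound 2 to compound 3 is estimated at a step that the limit leaves unreadable from compound 2 to compound 3, no change beyond the scatter. The estimated value for compound 3 in this assay is 40000 nM, with a range from 15000 nM to 100000 nM.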

Compound 3, concentration lethal to 50% of the cells: > 32500 nM
Compound 3: no number, only a limit; the forecaster's own chance of this, stated with the estimate: 85%; the middle value does not contradict the limit.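

In this assay compound 3 gives > 32500 nM as a limit of the assay and not a number. Among these compounds, no step from compound 2 or from compound 1 to compound 3 can therefore be read. The compounds shown leave open whether methoxy to hydroxy, or chloro in place of hydrogen, changes this read-out at all.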